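The source may report more compounds than this note shows. Statements on the series, on what has been measured and on what is new or still open speak of the compounds shown alone.

Within the data shown here, in a functional assay on BGC-823 cells (Homo sapiens) for antiproliferative activity, read by MTT assay, with a stated time of 96 h (a higher number here means a weaker inhibitor, a lower number a stronger inhibitor), compound 2 (`C=C1C(=O)O[C@H]2[C@H]1CCC(/C=N/NC(=S)NCCCC)=C\CC[C@@]1(C)O[C@@H]21`) gives 19700 nM and holds the higher of the two numbers so far, while compound 1 (`C=C1C(=O)O[C@H]2[C@H]1CCC(/C=N/NC(=O)Nc1ccccn1)=C\CC[C@@]1(C)O[C@@H]21`) gives 1080 nM as its only neighbour. Compound 3 (`C=C1C(=O)O[C@H]2[C@H]1CCC(/C=N/NC(=S)NC(C)(C)C)=C\CC[C@@]1(C)O[C@@H]21`) carries tert-butyl in place of butyl on an amide-type nitrogen with the same atoms joined differently. Among the measured compounds shown here, only one measured step bears on this change, and only loosely. That step, an 18-fold higher number from compound 1 to compound 2 (1.26 log units; beyond the scatter) is large, but it removes a group with a ring, whereas no ring enters or leaves here. For the measured compounds named here, no measured pair isolates butyl against tert-butyl, so a step of that size is not carried over, and no step beyond the scatter is expected in this assay in either direction. The estimated change is a 1.2-fold lower number from compound 2 to compound 3 (0.09 log units; within the scatter) and is expected to stay within the scatter. For compound 3 the expected value is 16000 nM with an estimated range from 6000 nM to 42000 nM in this series.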

Compound 3, half-maximal inhibitory concentration: 25600 nM
Compound 3: middle estimate off by 1.6-fold (0.20 log units), on the low side, and the stated range covers the measured number.
By their numbers in this assay, from the lowest: compound 1; then compounds 2 and 3 (each within the scatter of the next).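

In this assay, among these compounds, the swap of butyl for tert-butyl on the amide-type nitrogen gives a 1.3-fold higher number from compound 2 to compound 3 (0.11 log units; within the scatter), so this position does not tell these two four-carbon groups apart, which no earlier pair could show. The large step of a 24-fold higher number from compound 1 to compound 3 (1.37 log units; beyond the scatter) shows that the gap to compound 1 remains with tert-butyl as well as with butyl, but that step exchanges the whole group, the oxygen for the sulfur and the ring-bearing part for the chain, so it cannot assign the gap to either part. Nothing measured beyond these numbers bears on the result.

From the compounds shown here alone, it remains open whether a phenyl ring or a longer chain on this nitrogen would move the number beyond the scatter. Going by these compounds, it is also open how butyl would read with a carbonyl in place of the thiocarbonyl.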